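This account rests on a few compounds, and the source may have more. Where it says the series, first, only, none or still open, it means among the compounds named here.

Measured compounds in a functional assay on K562 cells (Homo sapiens) for antiproliferative activity, read by MTT assay, with a stated time of 48 h; a lower number here means a stronger inhibitor, a higher number a weaker inhibitor:

Compound 1 `CC(C)(C)OC(=O)CN1C(=O)C2(C(C#N)=C(N)Oc3cc4oc(-c5ccccc5)cc(=O)c4c(O)c32)c2ccccc21`: > 50000 nM
Compound 2 `N#CC1=C(N)Oc2cc3oc(-c4ccccc4)cc(=O)c3c(O)c2C12C(=O)Nc1ccccc12`: 36400 nM
Compound 3 `N#CC1=C(N)Oc2cc3oc(-c4ccccc4)cc(=O)c3c(O)c2C12C(=O)Nc1c(Cl)cccc12`: 37500 nM

The value given for compound 1 in this assay is a limit of the assay, not a number (the limit of > 50000 nM in this assay, at which 1 of the 3 values shown sits). Among the two numbers proper, compound 2 stands lowest; its nearest neighbour is compound 3, and the step of a 1.0-fold higher number from compound 2 to compound 3 (0.01 log units; within the scatter) lies within the scatter, so the two cannot be ordered. From compound 1 to compound 2 the step of an at least 1.3-fold lower number from compound 1 to compound 2 (0.13 log units; that floor lies within the scatter) is only a floor that itself lies within the scatter.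

Compound 4 `N#CC1=C(N)Oc2cc3oc(-c4ccccc4)cc(=O)c3c(O)c2C12C(=O)Nc1cc(Br)ccc12` is the next member. It differs from compound 2 by bromo in place of hydrogen on an aromatic carbon. Going by the values given here, the one measured step that bears on this change is the halogen placed on an aromatic carbon of the same ring, a 1.0-fold higher number from compound 2 to compound 3 (0.01 log units; within the scatter), which was within the scatter. A second halogen at another position on that ring is therefore expected to leave the number essentially where compound 2 sits, with no step beyond the scatter: a 1.0-fold higher number from compound 2 to compound 4 (0.01 log units; within the scatter) is the expected step from compound 2 to compound 4. For compound 4 the estimate in this assay is 37000 nM, expected to fall between 15000 nM and 90000 nM.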

Compound 4, half-maximal inhibitory concentration: 8700 nM
Compound 4: the middle estimate sits 4.3-fold (0.63 log units) above what was measured, outside the stated range (below it).
By their numbers in this assay, from the lowest: compound 4; then compounds 2 and 3 (each within the scatter of the next). At a limit, above all of these: compound 1.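

In this assay, bromo in place of hydrogen at this position, meta to a fused ring and para to a fused ring, gives a 4.2-fold lower number from compound 2 to compound 4 (0.62 log units; beyond the scatter), the only step shown that is both a full number and beyond the scatter, though it is modest. The chloro step on the same ring, a 1.0-fold higher number from compound 2 to compound 3 (0.01 log units; within the scatter), stayed within the scatter, so a halogen on this ring does not always leave the number unchanged, but these two steps differ in both the halogen and the carbon that carries it, and the compounds shown do not separate the two. Nothing among the data shown gives a reason for the bromo step.

Still open, from the compounds shown here alone, is whether the step follows the carbon or the halogen, which would take chloro on the carbon bearing bromo in compound 4, and bromo on the carbon bearing chloro in compound 3. Also open, going by these compounds, is whether a different group on that carbon, such as fluoro, methoxy, an amine or a carboxylic acid, would move the number further or return it to the level of compound 2.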